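Methoxy for methylsulfanyl on the benzylamine arm

The source may hold more compounds than are shown below. What is called first, only, known or untested is meant among the compounds shown, and "the series" means these compounds.

Compound 1 `CSc1ccc(CNc2nc(SC)nc3ncccc23)cc1` is the anchor of this comparison. In a functional assay on CCRF-CEM cells (Homo sapiens) for cytotoxicity, read by MTT assay, with a stated time of 72 h (on this read-out higher numbers stand for weaker inhibition of growth and lower numbers for stronger inhibition of growth), compound 1 gives 16800 nM, the lowest of the two numbers recorded, with compound 2 as its nearest neighbour. Compound 2 `CCCCC[Se]c1nc(NCc2ccc(SC)cc2)c2ccccc2n1` gives 83900 nM in this assay. Compound 3 `CSc1ccc(CNc2nc([SeH])nc3ccccc23)cc1` yields only a limit in this assay, > 100000 nM, as noted in the limit of > 100000 nM in this assay, at which 1 of the 3 values shown sits. Among the compounds with values here, the one measured step that differs in a single place, an at least 1.1-fold higher number from compound 2 to compound 3 (0.07 log units; that floor lies within the scatter), swaps pentyl for hydrogen on a selenium; it sits on a different part of the molecule from the change now considered and its floor lies within the scatter.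

Compound 4 `COc1ccc(CNc2nc(SC)nc3ncccc23)cc1` differs from compound 1 by methoxy in place of methylsulfanyl on an aromatic carbon. Within the data shown here, no measured step touches this position, so the step from compound 2 to compound 3 offers no direct guide. With nothing in the data pointing to a shift in either direction, the expected size of the step in this assay is none beyond the scatter. Compound 4 is therefore expected to show 22000 nM, with a range of 8000 nM to 70000 nM. The estimated step of a 1.3-fold higher number from compound 1 to compound 4 (0.12 log units; within the scatter) expresses that expectation.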

Compound 4, concentration for total growth inhibition: > 100000 nM
Compound 4 gave a limit, no number (the forecaster's own chance of this, stated with the estimate: 15%); middle value at least 4.5-fold (0.65 log units) away from the limit.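

Within the data shown here, all the earlier compounds carry methylsulfanyl at this place, so they could say nothing about what it contributes. In this assay the change to methoxy gives an at least 5.9-fold higher number from compound 1 to compound 4 (0.77 log units; beyond the scatter) and so shows that growth inhibition depends on the group at this aromatic carbon, para to a large group, even though the two groups match in their counts of heavy atoms, donors and acceptors and differ only in sulfur against oxygen. Compound 4 gives > 100000 nM which is a limit of the assay and not a number, so the step is only a floor and its full size stays unread, and compound 4 is not alone at this limit: the limit of > 100000 nM in this assay, at which 2 of the 4 values shown sit.

The compounds shown leave open whether methylsulfanyl itself is needed here or whether another group, such as ethylsulfanyl, a chlorine atom or an amine, would keep the value of compound 1. They also leave open whether the same swap would have a similar effect on the core of compound 2, which carries pentyl on a selenium.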